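The source may report more compounds than this note shows. Statements on the series, on what has been measured and on what is new or still open speak of the compounds shown alone.

Measured so far in a functional assay on KBVIN cells (Homo sapiens) for antiproliferative activity, read by sulforhodamine B assay, with a stated time of 3 days; a lower number here means that less compound is needed, a higher number that more compound is needed for the effect:
- compound 1 `CCC1=C(O)c2c(oc(-c3ccc(C)cc3)cc2=O)C(CC)(CC)C1=O`: 0.08 uM
- compound 2 `CCC1=C(O)c2c(oc(-c3ccc(OC)cc3)cc2=O)C(CC)(CC)C1=O`: 0.68 uM
- compound 3 `CCC1=C(O)c2c(oc(-c3cccc(F)c3)cc2=O)C(CC)(CC)C1=O`: 3.09 uM

Compound 3 has the highest number of the three, and the closest value is that of compound 2. Next is compound 4 `CCC1=C(O)c2c(oc(-c3ccc(C)c(F)c3)cc2=O)C(CC)(CC)C1=O`, which differs from compound 3 as follows: methyl in place of hydrogen on an aromatic carbon. This is methyl in place of hydrogen on an aromatic carbon, taking 3-fluorophenyl to 3-fluoro-4-methylphenyl.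

The most relevant measured step is a 39-fold higher number from compound 1 to compound 3 (1.59 log units; beyond the scatter), a large one, since compound 4 carries both the methyl of compound 1 and the fluoro of compound 3. The step of an 8.5-fold higher number from compound 1 to compound 2 (0.93 log units; beyond the scatter), which is modest, also shows sensitivity to the group at the position that gains the methyl. For the measured compounds named here, no measured compound yet carries both groups, so recovery of only part of the large step is expected. The expected change in this assay is a 7.7-fold lower number from compound 3 to compound 4 (0.89 log units; beyond the scatter), towards a lower number and beyond the scatter. For compound 4 the estimated value is 0.4 uM, with an expected range from 0.1 uM to 1.6 uM.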

Compound 4, concentration for half-maximal effect: 2.95 uM
The estimate for compound 4 lay 7.4-fold (0.87 log units) below the measured number; measured number outside the range, above it.
By their numbers in this assay, from the lowest: compound 1; then compound 2; then compounds 4 and 3 (each within the scatter of the next).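

In this assay methyl ortho to a fluoro group gives a 1.0-fold lower number from compound 3 to compound 4 (0.02 log units; within the scatter), so the methyl that accompanies the low number of compound 1 makes no readable difference once the fluoro group is present. Seen from the other side, fluoro in place of hydrogen gives a 37-fold higher number from compound 1 to compound 4 (1.57 log units; beyond the scatter), a large step that the methyl does not offset, and the replacement of 4-methoxyphenyl gives a 4.3-fold higher number from compound 2 to compound 4 (0.64 log units; beyond the scatter); this single fluoro change is as large as the earlier step from 4-methylphenyl to 3-fluorophenyl. No measurement at hand explains this dependence of the methyl on its neighbouring group.

Open, on these data alone, is whether chloro or hydroxyl in place of the fluoro group would also cancel the methyl. Also open, as far as these compounds go, is how an ethyl chain, an amine or a carboxylic acid in place of the methyl of compound 1 would read.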